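A few compounds are considered here, and "the series" means these few. Any claim that something is new, unique, unknown or untested is made for them only; others in the source may bear on it.

Measured so far:
compound 1 `CCSC(=S)SCC(=O)c1ccc(-c2ccc(CNc3cnc4ccccc4c3)cn2)s1` — 438 nM
compound 2 `CCSC(=S)SCC(=O)c1ccc(S(=O)(=O)Nc2ccc(Cl)cc2)cc1` — 340 nM

In an assay on HEK293 cells for inhibition of protein deacetylase HDAC6 (Homo sapiens) (a higher number here means a weaker inhibitor, a lower number a stronger inhibitor), compound 2 gives 340 nM, and compound 1 gives 438 nM; the two numbers lie within the scatter of each other, so neither compound can be set above the other. Compound 3 `CCSC(=S)SCC(=O)c1ccc(S(=O)(=O)Nc2ccc(OC)cc2)cc1` differs from compound 2 by methoxy in place of chloro on an aromatic carbon. Among the measured compounds shown here, no step between measured compounds shows the effect of this change, so no direction can be read from the data. The change is expected to move this assay little, if at all: compound 3 is estimated at 400 nM, with a range of 180 nM to 900 nM, a step of a 1.2-fold higher number from compound 2 to compound 3 (0.07 log units; within the scatter) that is expected to stay within the scatter.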

Compound 3, half-maximal inhibitory concentration: 245 nM
The estimate for compound 3 lay 1.6-fold (0.21 log units) above the measured number; the range from low to high includes it.
By their numbers in this assay, from the lowest: compounds 3, 2 and 1 (each within the scatter of the next).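

Replacing 4-chlorophenyl with 4-methoxyphenyl gives the first step read at this position, and in this assay it comes to a 1.4-fold lower number from compound 2 to compound 3 (0.14 log units; within the scatter) and no more. This position therefore holds either chloro or methoxy with no difference that can be told from the scatter, even though methoxy brings a hydrogen-bond acceptor that chloro lacks. Nothing available explains this result.

As far as these compounds go, whether an amine or a carboxylic acid on this aromatic carbon would stay as close remains open. So does whether a longer chain, such as butoxy, would do so.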